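Working notes: from compound 3 to compound 4

The compounds below may be only part of what the source reports. "The series", "measured", "known", "first", "only" and "open" are said of these compounds alone.

Values in an ADME assay on Karpas-1106P cells (Homo sapiens) for cytotoxicity (on this read-out lower numbers stand for an effect already at smaller amounts and higher numbers for an effect only at larger amounts of compound), so far
compound 1 `Cc1ccc(S(=O)(=O)N[C@@H](CC(=O)NC(C)(C)C)C(=O)NCCNC(=O)c2ccccc2)cc1` gives > 11100 nM as a limit
compound 2 `Cc1ccc(S(=O)(=O)N[C@@H](CC(=O)NC(C)(C)C)C(=O)NCCNC(=O)Nc2ccccc2)cc1` gives > 11100 nM as a limit
compound 3 `Cc1ccc(S(=O)(=O)N[C@@H](CC(=O)NC(C)(C)C)C(=O)NCCNC(=O)c2cccc(C(C)C)c2)cc1` gives > 11100 nM as a limit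

In this assay compound 3 has only the limit > 11100 nM and no number. It has no position of its own within the series, which shows the limit of > 11100 nM in this assay, at which 3 of the 3 values shown sit, and nothing else.

Compound 4 `Cc1ccc(S(=O)(=O)N[C@@H](CC(=O)NC(C)(C)C)C(=O)NCCNC(=O)c2c(O)cccc2F)cc1` is not yet measured. It carries 2-fluoro-6-hydroxyphenyl in place of 3-isopropylphenyl on a carbonyl carbon, and the count reads 2-fluoro-6-hydroxyphenyl in place of 3-isopropylphenyl on a carbonyl carbon with the rest of the structure unchanged.

Among the compounds with values here, three measured steps bear on this change. Two are exchanges on the same carbonyl carbon, namely a step that the two limits leave unreadable from compound 1 to compound 2 and also a step that the two limits leave unreadable from compound 2 to compound 3 in the same series. The third is a step that the two limits leave unreadable from compound 1 to compound 3 on the aromatic ring. None of them gives a size or a direction, so the data support no expected shift in either direction.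

The expected result is a step that the limit leaves unreadable from compound 3 to compound 4 as an estimate with no readable size behind it. For compound 4 the estimated value is 16000 nM as a rough figure. The expected range for compound 4 runs from 9000 nM to 40000 nM and a report as a limit is the likeliest outcome.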

Compound 4, half-maximal effective concentration: > 11100 nM
Compound 4: no number, only a limit; the forecaster's own chance of this, stated with the estimate: 85%; the middle value lies beyond the limit too.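

In this assay compound 4 gives > 11100 nM, a limit and not a number. No step between compound 4 and compounds 1, 2 or 3 can be read, because all of them sit at the same limit: the limit of > 11100 nM in this assay, at which 4 of the 4 values shown sit.

The compounds shown leave open whether any exchange on this carbonyl carbon shifts the read-out, and in which direction.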